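The source may hold more compounds than are shown below. What is called first, only, known or untested is meant among the compounds shown, and "the series" means these compounds.

Measured so far:
compound 1 `COc1cc(/C=C/C(=O)c2cccc(-n3cc(-c4ccccc4)[nH]c3=O)c2)cc(OC)c1OC` — in a functional assay on M14 cells (Homo sapiens) for inhibition (a higher number here means a weaker inhibitor of growth, a lower number a stronger inhibitor of growth), compound 1 gives 1350 nM
compound 2 `O=C(/C=C/c1cccc(O)c1)c1cccc(-n2cc(-c3ccc(Cl)cc3)[nH]c2=O)c1` — in this assay compound 2 gives 2010 nM

Of the compounds shown here, two carry a number so far. Compound 1 has the lower of the two, but the gap to compound 2 is within the scatter, so the two values show no real separation, and nothing about the size of any structural step between them is recorded.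

Compound 3 `COc1cc(/C=C/C(=O)c2cccc(-n3cc(-c4cc(OC)c(OC)c(OC)c4)[nH]c3=O)c2)cc(OC)c1OC` is the next compound to be measured. Relative to compound 1 the change is 3,4,5-trimethoxyphenyl in place of phenyl on an aromatic carbon. For the measured compounds named here, the change keeps the core of compound 1 and alters only one aromatic group on it.

Going by the values given here, no step between measured compounds is recorded, so the expected size of this step rests on the two values alone. In this assay the step from compound 1 to compound 3 is expected to be a 1.4-fold lower number from compound 1 to compound 3 (0.13 log units; within the scatter), a change that may well stay within the scatter, with no firm direction claimed. Compound 3 is therefore estimated at 1000 nM, in the range 300 nM to 4000 nM.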

Compound 3, concentration for 50% growth inhibition: 2120 nM
For compound 3 the middle estimate is 2.1-fold (0.33 log units) below the measured one; the measured number falls inside the stated range.
By their numbers in this assay, from the lowest: compounds 1, 2 and 3 (each within the scatter of the next).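

In this assay, placing 3,4,5-trimethoxyphenyl in place of phenyl on the aromatic carbon of the five-membered aromatic ring with 2 nitrogen gives a 1.6-fold higher number from compound 1 to compound 3 (0.20 log units; within the scatter). For the compounds shown here, this is the first step that can be read at a single place, and it shows that a group of 12 heavy atoms, including 3 oxygen, can replace one of 6 carbon atoms here with the read-out staying within the scatter of repeated measurements. No measurement on hand bears on the reason for this result.

The compounds shown leave open whether an amine, a carboxylic acid or a longer chain on this aromatic carbon would produce a step beyond the scatter. They also leave open whether the phenyl to 3,4,5-trimethoxyphenyl step would keep this size in a compound with a different second aromatic group, as this single pair is the only one that can be read so far.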